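A few compounds are considered here, and "the series" means these few. Any claim that something is new, unique, unknown or untested is made for them only; others in the source may bear on it.

Among the compounds with values here, compound 2 `CC(C)=CCC/C(C)=C/CC/C(C)=C/CC[C@]1(C)CCc2c(C)c(OC(=O)NCc3ccccc3)c(C)c(C)c2O1` is the one member of the series with a number in a functional assay on MDA-MB-231 cells (Homo sapiens) for antiproliferative activity, read by MTT assay, with a stated time of 96 h; on this read-out higher numbers stand for weaker inhibition and lower numbers for stronger inhibition: compound 2 gives 7200 nM. Compound 1 `CC(C)=CCC/C(C)=C/CC/C(C)=C/CC[C@]1(C)CCc2c(C)c(OC(=O)NS(=O)(=O)c3ccc(C)cc3)c(C)c(C)c2O1` reaches only the limit of this assay, > 10000 nM. Compound 3 `CC(C)=CCC/C(C)=C/CC/C(C)=C/CC[C@]1(C)CCc2cc(OC(=O)NCc3ccccc3)c(C)c(C)c2O1` likewise stops at the limit, > 10000 nM. Both measured steps, an at least 1.3-fold lower number from compound 1 to compound 2 (0.14 log units; that floor lies within the scatter) and an at least 1.3-fold higher number from compound 2 to compound 3 (0.14 log units; that floor lies within the scatter), are floors set by the limit of > 10000 nM in this assay, at which 2 of the 3 values shown sit, rather than sized steps. Compound 4 `CC(C)=CCC/C(C)=C/CC/C(C)=C/CC[C@]1(C)CCc2c(C)c(O)c(C)c(C)c2O1` differs from compound 2 as follows: hydrogen in place of benzylcarbamoyl on an oxygen on an aromatic ring. Neither measured step removes the benzylcarbamoyl group from the oxygen on the aromatic ring; one alters the substituent on the amide-type nitrogen, the other a methyl on an aromatic carbon, so neither bears directly on this change. No step beyond the scatter is therefore expected, and compound 4 is estimated at 9000 nM, between 3000 nM and 27000 nM, meaning an expected step of a 1.3-fold higher number from compound 2 to compound 4 (0.10 log units; within the scatter).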

Compound 4, half-maximal inhibitory concentration: > 10000 nM
Compound 4 ended at the assay's limit; the forecaster's own chance of this, stated with the estimate: 40%; middle value at least 1.1-fold (0.04 log units) away from the limit.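

Hydrogen in place of benzylcarbamoyl on the oxygen on the aromatic ring gives an at least 1.3-fold higher number from compound 2 to compound 4 (0.14 log units; that floor lies within the scatter), the only step in this assay that changes this position directly. Compound 4 stops at a limit, > 10000 nM. The benzylcarbamoyl group therefore cannot be credited with a sized contribution, and the step remains only a floor: the limit of > 10000 nM in this assay, at which 3 of the 4 values shown sit.

Going by these compounds, it remains open how far compound 4 actually lies from compound 2. Also open, on these data alone, is whether an acetyl or methyl group on this oxygen, or a longer chain in place of benzyl on the nitrogen, would give a readable number.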